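Adding a Benzoyloxy Group to a Rapidly Cleaved Ester

The source may hold more compounds than are shown below. What is called first, only, known or untested is meant among the compounds shown, and "the series" means these compounds.

Of the compounds shown here, two have so far been measured in an ADME assay on a cell-free system (plasma, Homo sapiens) for metabolic stability, with Plasma (Rattus norvegicus) as the target, read by HPLC, at pH 7.4; on this read-out higher numbers stand for a longer-lived compound and lower numbers for a shorter-lived compound. Compound 1 `CCC(=O)O[C@@H]1CO[C@H]2[C@@H]1OC[C@@H]2OC(=O)c1ccccc1OC(C)=O` gives 0.011 h in this assay. Compound 2 `CC(=O)Oc1ccccc1C(=O)O[C@H]1CO[C@H]2[C@@H]1OC[C@H]2OC(=O)c1ccccc1` gives 0.0107 h in this assay. These two differ only in the group on one carbonyl carbon, phenyl in compound 2 in place of ethyl in compound 1, and the result was a 1.0-fold lower number from compound 1 to compound 2 (0.01 log units; within the scatter). For the measured compounds named here, compound 2 has the lowest of the two numbers, but its only neighbour, compound 1, lies within the scatter of it, so the two cannot be told apart.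

Compound 3 `CC(=O)Oc1ccccc1C(=O)O[C@H]1CO[C@H]2[C@@H]1OC[C@H]2OC(=O)c1ccccc1OC(=O)c1ccccc1` has not yet been measured. It differs from compound 2 by benzoyloxy in place of hydrogen on an aromatic carbon. Going by the values given here, the only measured step, from compound 1 to compound 2, changed a carbonyl substituent and moved nothing beyond the scatter; it does not test a benzoyloxy group on an aromatic carbon, so it gives only weak guidance. Both measured compounds are very short-lived in this assay. For compound 3 the expected step is a 1.0-fold higher number from compound 2 to compound 3 (0.01 log units; within the scatter), with no clear direction. The estimate for compound 3 in this assay is 0.011 h, with a range from 0.005 h to 0.025 h.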

Compound 3, half-life: 0.0722 h
For compound 3 the middle estimate is 6.6-fold (0.82 log units) below the measured one; the measured number lies above the stated range.
By their numbers in this assay, from the lowest: compounds 2 and 1 (each within the scatter of the next); then compound 3.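

In this assay, for the compounds shown here, benzoyloxy in place of hydrogen on an aromatic carbon, ortho to a large group, gives a 6.7-fold higher number from compound 2 to compound 3 (0.83 log units; beyond the scatter), the first step in this small set to pass beyond the scatter. This shows that the read-out can respond to a change at this aromatic position, even though the step is only modest in size. The earlier swap, phenyl in place of ethyl on a carbonyl carbon, gave a 1.0-fold lower number from compound 1 to compound 2 (0.01 log units; within the scatter), so it offered no such sign. Nothing measured here explains why the number rises at this position.

The compounds shown leave open whether this step belongs to benzoyloxy in particular, or whether a smaller group on the same aromatic carbon, such as methoxy or a chlorine atom, would give a similar step. They also leave open whether benzoyloxy would give a step of the same size on compound 1, where ethyl stands on the carbonyl carbon in place of phenyl.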